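This account rests on a few compounds, and the source may have more. Where it says the series, first, only, none or still open, it means among the compounds named here.

Among the compounds with values here, compound 2, `CCCCNc1nc(N)nc2cccc(C(=O)NC(C)C)c12`, gives 15.6 uM in an ADME assay on HEK293 cells for agonist activity at Toll-like receptor 8 (Homo sapiens), read by a luciferase reporter, with a stated time of 6 h (a higher number here means that more compound is needed for the effect, a lower number that less compound is needed), the higher of the two numbers measured so far. Compound 1, `CCCCNc1nc(N)nc2cccc(C)c12`, gives 0.3 uM, and the step of a 52-fold higher number from compound 1 to compound 2 (1.72 log units; beyond the scatter) is large. Compound 3, `CCCCNc1nc(N)nc2cccc(C(=O)N[C@H](C)c3ccccc3)c12`, differs from compound 2 by 1-phenylethyl in place of isopropyl on an amide-type nitrogen. Within the data shown here, the one measured step replaced a group on an aromatic carbon, not on the amide nitrogen, so no measured step bears directly on this change. The expected step is therefore small, a 2.0-fold lower number from compound 2 to compound 3 (0.29 log units; within the scatter), with wide uncertainty. Compound 3 is estimated at 8 uM, between 2 uM and 40 uM.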

Compound 3, minimum effective concentration: > 25 uM
Compound 3 ended at the assay's limit; the forecaster's own chance of this, stated with the estimate: 10%; at least 3.1-fold (0.49 log units) between middle value and limit.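

In this assay compound 3 gives > 25 uM, which is a limit of the assay and not a number. Within the data shown here, this is the first measured change on the amide-type nitrogen, and 1-phenylethyl in place of isopropyl brings no lower number: the step is an at least 1.6-fold higher number from compound 2 to compound 3 (0.20 log units; that floor lies within the scatter), a floor whose true size cannot be read. The ceiling on what this comparison can show is set by the assay: the limit of > 25 uM in this assay, at which 1 of the 3 values shown sits.

On these data alone, whether a smaller group on that nitrogen, such as methyl, or a chain ending in an amine would lower the number remains open. So does the effect of the mirror-image 1-phenylethyl group.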